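Aminophenyl enones: removing one methoxy from the trimethoxyphenyl ring

The source may hold more compounds than are shown below. What is called first, only, known or untested is meant among the compounds shown, and "the series" means these compounds.

Three members of the series carry a measurement in a functional assay on T47D cells (Homo sapiens) for inhibition, read by sulforhodamine B assay, with a stated time of 48 h; on this read-out higher numbers stand for weaker inhibition of growth and lower numbers for stronger inhibition of growth. Compound 1 `COc1ccc(-c2cc(/C=C/C(=O)c3ccc(N)cc3)[nH]n2)cc1` gives 9770 nM. Compound 2 `COc1cc(-c2cc(/C=C/C(=O)c3ccc(N)cc3)[nH]n2)cc(OC)c1OC` gives 4300 nM and stands lowest of the three; its nearest neighbour is compound 1, which sits beyond the scatter from it, and the furthest is compound 3 `COc1cc(-c2cc(/C=C/C(=O)c3ccc(F)c(F)c3)[nH]n2)cc(OC)c1OC`, which gives 27000 nM. For the measured compounds named here, the only single-point step recorded so far, a 6.3-fold higher number from compound 2 to compound 3 (0.80 log units; beyond the scatter), concerns the ring on the carbonyl carbon and tells nothing about the methoxy pattern on the other aryl ring.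

Compound 4 `COc1ccc(-c2cc(/C=C/C(=O)c3ccc(N)cc3)[nH]n2)cc1OC` differs from compound 2 by hydrogen in place of methoxy on an aromatic carbon. Going by the values given here, no measured pair isolates this change. What the numbers do show is that compound 1, with a single methoxy on that ring, and compound 2, with three, sit on either side of where compound 4 would fall by substituent count, and those two values lie beyond the scatter from one another. Among the compounds with values here, with no step of its own to lean on, compound 4 is expected to land between them, most likely somewhat weaker than compound 2, so the expected step of a 1.5-fold higher number from compound 2 to compound 4 (0.18 log units; within the scatter) is modest. The estimate for compound 4 in this assay is 6500 nM, with a range from 2500 nM to 16000 nM.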

Compound 4, concentration for total growth inhibition: 26000 nM
Beside the measured number, compound 4's estimate is 4.0-fold (0.60 log units) below it, outside the stated range (above it).
By their numbers in this assay, from the lowest: compound 2; then compound 1; then compounds 4 and 3 (each within the scatter of the next).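

In this assay, the methoxy at this position carries real weight in the aminophenyl series: hydrogen in its place gives a 6.0-fold higher number from compound 2 to compound 4 (0.78 log units; beyond the scatter) and so costs growth inhibition beyond the scatter. The other neighbour moves the same way, with a 2.7-fold higher number from compound 1 to compound 4 (0.43 log units; beyond the scatter) on adding a methoxy to the ring of compound 1, so taking a methoxy away from compound 2 and adding one to compound 1 both arrive at a higher number at compound 4. Across compounds 1, 2 and 4, the number therefore does not follow the count of methoxy groups, and compound 4 does not fall in the middle; no measurement at hand explains this turn.

Still open, from the compounds shown here alone, is whether the methoxy itself matters at this position of compound 2, or whether a hydroxyl, an ethoxy or a fluorine there would hold the lower number of compound 2. Also open, going by these compounds, is whether the same hydrogen for methoxy change behaves alike when the 3,4-difluorophenyl group of compound 3 sits on the carbonyl carbon in place of the 4-aminophenyl group.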